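This account rests on a few compounds, and the source may have more. Where it says the series, first, only, none or still open, it means among the compounds named here.

Measured so far:
compound 1, `Cc1cccc(/C=C/c2nnc(-c3ccc4c(c3)OCCO4)o2)c1`: 201000 nM
compound 2, `O=[N+]([O-])c1ccc(/C=C/c2nnc(-c3ccc4c(c3)OCCO4)o2)cc1`: 299000 nM

Among the measured compounds shown here, in an ADME assay on HUVEC cells (Homo sapiens) for cytotoxicity, read by MTT assay, with a stated time of 24 h (a higher number here means that more compound is tolerated, a lower number that less compound is tolerated), compound 2 gives the larger of the two recorded numbers, 299000 nM, but its only neighbour, compound 1 at 201000 nM, lies within the usual scatter of it, so the two compounds are not separated by the data. Both tolerate a great deal of compound before cells are affected.

Compound 3, `Clc1ccc(/C=C/c2nnc(-c3ccc4c(c3)OCCO4)o2)cc1`, is the next member. It differs from compound 2 in one place: chloro in place of nitro on an aromatic carbon.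

For the measured compounds named here, no measured pair in this set isolates such a change, so there is no recorded step to lean on. Both known members sit close together at the upper end of the tolerated range, and nothing in the data points to either direction. In this assay the step is expected to be small, at most at the edge of the scatter, with no clear direction.

The estimate for compound 3 in this assay is 250000 nM, within 120000 nM to 500000 nM, which would mean a step of a 1.2-fold lower number from compound 2 to compound 3 (0.08 log units; within the scatter) from the value of compound 2.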

Compound 3, half-maximal cytotoxic concentration: 312000 nM
For compound 3 the middle estimate is 1.2-fold (0.10 log units) below the measured one, within the range that was stated.
By their numbers in this assay, from the lowest: compounds 1, 2 and 3 (each within the scatter of the next).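

In this assay chloro in place of nitro on an aromatic carbon, para to a large group, gives a 1.0-fold higher number from compound 2 to compound 3 (0.02 log units; within the scatter) and so leaves no separable difference, even though a group with hydrogen-bond acceptors gives way to one with none. This position of the six-membered aromatic ring therefore accepts both groups in this assay without a change the data can resolve. The wider change of 4-chlorophenyl in place of 3-methylphenyl gives a 1.6-fold higher number from compound 1 to compound 3 (0.19 log units; within the scatter) and likewise stays unresolved, and no supporting measurement explains the flat result.

As far as these compounds go, whether an amine or a carboxylic acid on the same aromatic carbon would stay equally well tolerated remains open. Also open, from the compounds shown here alone, is whether any change to the shared core would separate compounds in this assay.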